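Removing a Methyl from Two Cores in a Cell Assay

The compounds below may be only part of what the source reports. "The series", "measured", "known", "first", "only" and "open" are said of these compounds alone.

Compound 1 `COc1ccc(C(=O)NNC(=S)Nc2csc(-c3ccc(C)cc3)c2)cc1` and compound 2 `Cc1ccc(-c2cc(NC(=S)NNC(=O)c3ccc(O)cc3)cs2)cc1` share one core, while compound 3 `COc1ccc(-c2nnc(Nc3csc(-c4ccccc4)c3)s2)cc1` and compound 4 `Oc1ccc(-c2nnc(Nc3csc(-c4ccccc4)c3)s2)cc1` share another; how the two cores differ is not broken down here. In a functional assay on SK-MEL-28 cells (Homo sapiens) for inhibition, read by colorimetric assay and MTT assay, with a stated time of 72 h (on this read-out lower numbers stand for stronger inhibition and higher numbers for weaker inhibition), compound 1 gives 11000 nM. Compound 2 gives 46000 nM in this assay. The change between them, (hydrogen in place of methyl on an oxygen on an aromatic ring), produced a 4.2-fold higher number from compound 1 to compound 2 (0.62 log units; beyond the scatter). Compound 3 gives > 100000 nM in this assay, which is a limit rather than a number, as the limit of > 100000 nM in this assay, at which 1 of the 3 values shown sits, records. The same change, (hydrogen in place of methyl on an oxygen on an aromatic ring), leads from compound 3 to compound 4. Compound 4 is expected to show a step that the limit leaves unreadable from compound 3 to compound 4, an expectation resting on a 4.2-fold higher number from compound 1 to compound 2 (0.62 log units; beyond the scatter) and on compound 3 already sitting at the limit of > 100000 nM in this assay, at which 1 of the 3 values shown sits. Compound 4 is therefore estimated at 250000 nM, and it is expected that this assay again reports only a limit.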

Compound 4, half-maximal inhibitory concentration: 57000 nM
For compound 4 the middle estimate is 4.4-fold (0.64 log units) above the measured one; measured number below the stated range.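

In this assay, the change from methoxy to hydroxy gave an at least 1.7-fold lower number from compound 3 to compound 4 (0.24 log units; that floor lies within the scatter), which runs opposite to the higher number seen on the core of compound 1. The change therefore did not carry over from one core to the other, and the two steps are clearly separated: the same change on two cores in this assay, a 4.2-fold higher number (0.62 log units; beyond the scatter) from compound 1 to compound 2 and an at least 1.7-fold lower number (0.24 log units; that floor lies within the scatter) from compound 3 to compound 4, at least 7.3-fold (0.86 log units) apart, beyond the scatter of two such steps. Compound 3 is recorded only as a limit, so the full size of its step remains unknown, and these data do not show which part of the two cores accounts for the difference: the limit of > 100000 nM in this assay, at which 1 of the 4 values shown sits.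

The compounds shown leave open how an amine or a carboxylic acid in place of the hydroxy would behave on either core. They also leave open whether the methoxy to hydroxy change would follow either direction on a further core.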